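Imidazole amide series: cytotoxicity readings at the assay limit

The compounds below may be only part of what the source reports. "The series", "measured", "known", "first", "only" and "open" are said of these compounds alone.

Measured compounds:
- compound 1, `Cn1c(-c2cccc(Cl)c2)cnc1NC(=O)c1ccc(F)cc1`; in a toxicity assay on THP-1 cells (Homo sapiens) for inhibition (on this read-out higher numbers stand for lower toxicity in this test and lower numbers for higher toxicity in this test), compound 1 gives > 50000 nM, a limit of the assay and not a number.
- compound 2, `CCCCn1c(-c2ccc(OC)cc2)cnc1NC(=O)c1ccc(F)cc1`; in this assay compound 2 gives > 100000 nM, again a limit of the assay.
- compound 3, `COc1ccc(CNC(=O)NC(=O)c2ccc(F)cc2)cc1`; in this assay compound 3 gives > 50000 nM, also a limit of the assay.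

Where compound 1 stands: no number is known for it, only a limit. Every value in the set is a limit, so no order among the three can be read; the limit of > 50000 nM in this assay, at which 2 of the 3 values shown sit, and the limit of > 100000 nM in this assay, at which 1 of the 3 values shown sits, say where the readings sit, and nothing more.

The compound to be measured is compound 4, `Cn1c(-c2ccc(F)cc2)cnc1NC(=O)c1ccc(F)cc1`. It differs from compound 1 as follows: 4-fluorophenyl in place of 3-chlorophenyl on an aromatic carbon.

Among the compounds with values here, no step between two measured compounds is known, so there is no measured change to lean on. Given that compound 1 gives only a limit in this assay, the expectation for the move to compound 4 is a step that the limit leaves unreadable from compound 1 to compound 4, that is, none beyond the scatter, with the new reading most likely also reported as a limit. Compound 4 is therefore estimated at 60000 nM, within a range from 30000 nM to 150000 nM.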

Compound 4, half-maximal cytotoxic concentration: > 100000 nM
Compound 4 gave a limit, no number; the forecaster's own chance of this, stated with the estimate: 85%; middle value at least 1.6-fold (0.22 log units) away from the limit.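

In this assay compound 4 gives > 100000 nM, a limit of the assay and not a number. Compound 1 also gives only a limit, > 50000 nM, so no step can be read between compound 1 and compound 4. The compounds shown leave open whether 4-fluorophenyl and 3-chlorophenyl differ at all on this read-out, as no compound here has a numerical reading.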